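Benzyl on an aromatic nitrogen of compound 2

The compounds below may be only part of what the source reports. "The series", "measured", "known", "first", "only" and "open" are said of these compounds alone.

Measured in an ADME assay for permeability, using PAMPA, at pH 5.5 (on this read-out higher numbers stand for higher permeability and lower numbers for lower permeability), so far:
compound 1 `Nc1c(C(=O)N[C@@H]2CCCc3c(OCc4ccccc4)cccc32)[nH]c(=O)[nH]c1=O` gives 960 nm/s
compound 2 `O=C(N[C@H]1CC[C@@H](c2ccccc2)CC1)c1[nH]c(=O)[nH]c(=O)c1O` gives 427 nm/s

Compound 2 holds the lower of the two numbers, and its gap to compound 1 lies beyond the scatter. Compound 3 `O=C(N[C@H]1CC[C@@H](c2ccccc2)CC1)c1[nH]c(=O)n(Cc2ccccc2)c(=O)c1O` carries benzyl in place of hydrogen on an aromatic nitrogen of compound 2. Within the data shown here, no measured pair shows this change, so the expectation is loose. In this assay a small rise is expected, near the edge of the scatter, with an estimated 2.0-fold higher number from compound 2 to compound 3 (0.30 log units; within the scatter) as the step. For compound 3 the estimated value is 850 nm/s within an expected range of 300 nm/s to 2000 nm/s.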

Compound 3, apparent permeability: 277 nm/s
Beside the measured number, compound 3's estimate is 3.1-fold (0.49 log units) above it; measured number outside the range, below it.
By their numbers in this assay, from the lowest: compounds 3 and 2 (each within the scatter of the next); then compound 1.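

In this assay, among these compounds, benzyl in place of hydrogen on an aromatic nitrogen gives a 1.5-fold lower number from compound 2 to compound 3 (0.19 log units; within the scatter) and is the only reading so far at this position. Here, a carbon-only aromatic ring two atoms from the ring nitrogen enters without a step beyond the scatter. Nothing on hand gives a cause for this step.

Open, on these data alone, is whether a smaller group such as methyl on the same nitrogen also stays within the scatter. Also open, as far as these compounds go, is whether an amine or a carboxylic acid on the benzyl ring does.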